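A few compounds are considered here, and "the series" means these few. Any claim that something is new, unique, unknown or untested is made for them only; others in the source may bear on it.

Measured in a functional assay on RAW264.7 cells (Mus musculus) for inhibition, read by Griess assay, with stated times of 2 h and 24 h (on this read-out lower numbers stand for stronger inhibition and higher numbers for weaker inhibition), so far:

compound 1 `COc1ccc([C@@H]2CC(=O)c3c(O)cc(OCc4cn(Cc5cccc(Cl)c5)nn4)cc3O2)cc1O` — 18200 nM
compound 2 `COc1ccc([C@@H]2CC(=O)c3c(O)cc(OCc4cn(Cc5ccccc5C(F)(F)F)nn4)cc3O2)cc1O` — 12500 nM
compound 3 `COc1ccc([C@@H]2CC(=O)c3c(O)cc(OCc4cn(C)nn4)cc3O2)cc1O` — 15200 nM

Compound 3 holds the second highest of the three numbers. Its nearest neighbour is compound 1, with a 1.2-fold lower number from compound 1 to compound 3 (0.08 log units; within the scatter); further off is compound 2, with a 1.2-fold higher number from compound 2 to compound 3 (0.08 log units; within the scatter). The remaining pair, a 1.5-fold lower number from compound 1 to compound 2 (0.16 log units; within the scatter), is also within the scatter, so the three measured compounds cannot be ordered on this read-out.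

Compound 4 `COc1ccc([C@@H]2CC(=O)c3c(O)cc(OCc4cn(Cc5ccccc5C)nn4)cc3O2)cc1O` differs from compound 3 by 2-methylphenyl in place of hydrogen on a saturated chain carbon bound to an aromatic nitrogen. The two steps that bear on this are a 1.2-fold lower number from compound 1 to compound 3 (0.08 log units; within the scatter) and a 1.2-fold higher number from compound 2 to compound 3 (0.08 log units; within the scatter), each read in reverse: in both, a substituted phenyl ring was placed on the same saturated chain carbon bound to an aromatic nitrogen, and in neither case did the number move beyond the scatter. On that basis the step of a 1.1-fold lower number from compound 3 to compound 4 (0.04 log units; within the scatter) is expected to be small, with no direction that can be called beyond the scatter. Compound 4 is therefore estimated at 14000 nM, within a range of 7000 nM to 28000 nM.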

Compound 4, half-maximal inhibitory concentration: 13100 nM
Compound 4: the middle estimate sits 1.1-fold (0.03 log units) above what was measured; low and high end bracket the measured number.
By their numbers in this assay, from the lowest: compounds 2, 4, 3 and 1 (each within the scatter of the next).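

In this assay, 2-methylphenyl in place of hydrogen on a saturated chain carbon bound to an aromatic nitrogen gives a 1.2-fold lower number from compound 3 to compound 4 (0.06 log units; within the scatter) and thus a third aryl variant at this position that stays within the scatter of the plain methyl. New here is a change on the ring itself: methyl in place of trifluoromethyl on an aromatic carbon gives a 1.0-fold higher number from compound 2 to compound 4 (0.02 log units; within the scatter) while 2-methylphenyl in place of 3-chlorophenyl gives a 1.4-fold lower number from compound 1 to compound 4 (0.14 log units; within the scatter) and both steps lie within the scatter. No supporting data bear on why this position responds so little.

As far as these compounds go, whether any group at this position can move the number beyond the scatter stays open. A primary amine or a carboxylic acid on the phenyl ring, or a longer alkyl chain in place of the methyl, would test this.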